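A few compounds are considered here, and "the series" means these few. Any claim that something is new, unique, unknown or untested is made for them only; others in the source may bear on it.

Of the compounds shown here, three built around the same core have been measured in a functional assay on the whole organism (Tail, strain ICR) with Mus musculus as the target, in the tail flick test, with a stated time of 60 min, at a dose of 25 umol/kg by the oral route; a lower number here means a weaker effect, a higher number a stronger effect of the compound at the dose given. Compound 1, `O=C(CN(c1ncnc2c1ncn2C1CCCCO1)C1CC1)N[C@@H](CO)C(=O)OCc1ccccc1`, gives 46.7%. Compound 2, `O=C(OCc1ccccc1)[C@@H]1CCCN1C(=O)CN(c1nc(Cl)nc2[nH]cnc12)C1CC1`, gives 34.4%. Compound 3, `O=C(CN(c1nc(Cl)nc2[nH]cnc12)C1CC1)NCC(=O)OCc1ccccc1`, gives 41.9%. Of these three numbers, compound 1 has the highest. Its gap to compound 3 lies within the scatter of the test, so those two cannot be told apart, while its gap to compound 2 lies beyond the scatter, so compound 1 reads as the more active of that pair.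

Compound 4, `O=C(CN(c1ncnc2c1ncn2C1CCCCO1)C1CC1)NCC(=O)OCc1ccccc1`, has not yet been measured. It differs from compound 1 in one place: hydrogen in place of hydroxymethyl on a saturated chain carbon bound to an amide-type nitrogen and a carbonyl carbon. Among the measured compounds shown here, no pair of measured compounds differs by exactly this change, so no measured step can be borrowed for it. What can be said is that compound 3, which also lacks the hydroxymethyl, gives 41.9%, a number close to that of compound 1, although compound 3 carries a different core. On that basis the change is expected to move the number only a little. The expected step is a number 4.7 percentage points lower from compound 1 to compound 4 (within the scatter), a shift that would stay within the scatter. Compound 4 is therefore estimated at 42%, with a likely range from 28% to 56%.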

Compound 4, a percentage reported as activity, at one dose (the size of the read-out at that dose, not a potency): 40.4%
Compound 4: middle estimate off by 1.6 percentage points, on the high side, and the stated range covers the measured number.
By their numbers in this assay, from the lowest: compounds 2, 4, 3 and 1 (each within the scatter of the next, the first and the last beyond it).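

Among the compounds shown here, removing the hydroxymethyl and leaving hydrogen on the saturated chain carbon bound to an amide-type nitrogen and a carbonyl carbon gives the first direct reading of this change on a fixed core: in this assay the step is a number 6.3 percentage points lower from compound 1 to compound 4 (within the scatter) and the rest of the molecule stays the same. Within the scatter of this test, compound 1 and compound 4 cannot be told apart, so this group, with its one hydrogen-bond donor and one hydrogen-bond acceptor, shows no clear contribution to the read-out at this dose. No measurement is available that would explain this result at the level of the molecule.

Going by these compounds, whether a methyl group, a longer chain such as hydroxyethyl, an aminomethyl group or a carboxylic acid at this place would also leave the number within the scatter remains open. Also open, on these data alone, is whether compound 1 and compound 4 would stay this close at other doses and times, as a reading at one dose shows the size of the effect there and not a potency.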